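The compounds below may be only part of what the source reports. "The series", "measured", "known", "first", "only" and "open" are said of these compounds alone.

Measured so far:
Compound 1, `O=S(=O)(c1cc(F)cc(F)c1)c1cnc2c(F)cccc2c1-c1ccccc1F`, in an ADME assay on microsomes from liver (Homo sapiens) for metabolic stability, tested at 2.5 uM (on this read-out lower numbers stand for slow clearance and higher numbers for fast clearance), gives 0.09 mL/min.
Compound 2, `O=S(=O)(c1ccc(F)c(Cl)c1)c1cnc2c(F)cccc2c1-c1ccccc1F`, in this assay gives 1.39 mL/min.
Compound 3, `O=S(=O)(c1cc(Cl)cc(Cl)c1)c1cnc2c(F)cccc2c1-c1ccc(F)cc1`, in this assay gives 1.01 mL/min.

Compound 3 stands second highest of the three numbers. Its value sits close to that of compound 2, a gap within the usual scatter, while compound 1 lies well below both, a gap beyond the scatter. Going by the values given here, the one step measured between single-point neighbours is the swap on the sulfonyl sulfur, a 15-fold higher number from compound 1 to compound 2 (1.19 log units; beyond the scatter).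

Compound 4, `O=S(=O)(c1cc(Cl)cc(Cl)c1)c1cnc2c(F)cccc2c1-c1ccccc1F`, has not yet been measured. It keeps the 3,5-dichlorophenyl of compound 3 on the sulfonyl sulfur, and the change is elsewhere: 2-fluorophenyl in place of 4-fluorophenyl on an aromatic carbon. Among the compounds with values here, no measured pair shows this swap of 2-fluorophenyl for 4-fluorophenyl; the only step in hand concerns the other aryl ring, so it does not bear on it. With nothing to point one way or the other, the step of a 1.0-fold lower number from compound 3 to compound 4 (0.00 log units; within the scatter) is expected to stay within the scatter. Compound 4 is therefore estimated in this assay at about 1 mL/min, with a range from 0.45 mL/min to 2.2 mL/min.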

Compound 4, intrinsic clearance in a liver preparation (reported as CLH), per the amount of preparation that the assay uses: 0.44 mL/min
For compound 4 the middle estimate is 2.3-fold (0.36 log units) above the measured one; the whole stated range lies above it.
By their numbers in this assay, from the lowest: compound 1; then compound 4; then compounds 3 and 2 (each within the scatter of the next).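

In this assay, going by these compounds alone, the exchange of 4-fluorophenyl for 2-fluorophenyl gives the first reading at this position on the core, and the change is not silent (a 2.3-fold lower number from compound 3 to compound 4 (0.36 log units; beyond the scatter)). The two groups have the same atoms and the same counts, so relocating one fluorine on this ring is enough to move the number beyond the scatter. With 2-fluorophenyl held constant, the aryl group on the sulfonyl sulfur now has three readings, placing 3,5-dichlorophenyl above 3,5-difluorophenyl (a 4.9-fold higher number from compound 1 to compound 4 (0.69 log units; beyond the scatter)) and below 3-chloro-4-fluorophenyl (a 3.2-fold lower number from compound 2 to compound 4 (0.50 log units; beyond the scatter)), and no measurement at hand explains any of these steps.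

Going by these compounds, the exchange at this position can be read only with 3,5-dichlorophenyl on the sulfonyl sulfur, so it remains open whether a similar step would appear with 3,5-difluorophenyl or 3-chloro-4-fluorophenyl there. Also open, on these data alone, is how the number would respond at this position to 3-fluorophenyl, to plain phenyl, or to a ring carrying an amine or a carboxylic acid.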